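From methyl to methoxy on an inactive-looking compound

The source may hold more compounds than are shown below. What is called first, only, known or untested is meant among the compounds shown, and "the series" means these compounds.

In a functional assay on HCT-15 cells (Homo sapiens) for cytotoxicity, read by MTT assay, with a stated time of 2 days (on this read-out higher numbers stand for weaker inhibition and lower numbers for stronger inhibition), compound 2 (`Cc1cccc(-c2nc3ccc(C)cc3c(=O)[nH]2)c1`) gives > 50000 nM as a limit and not a number. Compound 3 (`Cc1ccc2nc(-c3cccc4ccccc34)[nH]c(=O)c2c1`) also gives > 50000 nM as a limit. Only compound 1 (`CN(C)c1ccc2nc(-c3cccc4ccccc34)[nH]c(=O)c2c1`) reads as a true number, with 460 nM on this scale. Within the data shown here, the one measured step is an at least 100-fold higher number from compound 1 to compound 3 (2.03 log units; beyond the scatter) and it is large, yet it swaps dimethylamino for methyl, so it bears only loosely on a different swap. Compound 4 (`COc1cccc(-c2nc3ccc(C)cc3c(=O)[nH]2)c1`) has methoxy in place of methyl on an aromatic carbon. Among the measured compounds shown here, no large step and no firm direction is expected in this assay (a number no higher from compound 2 to compound 4 (the limit leaves the size open)). For compound 4 the estimated value is 50000 nM (expected range 15000 nM to 100000 nM) and a limit alone may well be reported.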

Compound 4, half-maximal inhibitory concentration: 32000 nM
Beside the measured number, compound 4's estimate is 1.6-fold (0.19 log units) above it; low and high end bracket the measured number.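

Methoxy in place of methyl on this aromatic carbon, meta to a large group, gives an at least 1.5-fold lower number from compound 2 to compound 4 (0.19 log units; that floor lies within the scatter) in this assay. Among these compounds, compound 4 reads as a true number, 32000 nM, so this position now has one real value on the scale, still far weaker than the one true number seen before it. The real size of the step stays unknown because compound 2 gives only a limit: the limit of > 50000 nM in this assay, at which 2 of the 4 values shown sit.

The compounds shown leave open how an amine or a carboxylic acid would read on this aromatic carbon. They also leave open whether a longer chain, such as propoxy, would read any differently from methoxy.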